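The source may hold more compounds than are shown below. What is called first, only, known or untested is meant among the compounds shown, and "the series" means these compounds.

Compound 3 `CC(C)[C@@H](NC(=O)c1nc2ccccc2s1)C(=O)N1CCC(c2ccc(Cl)cc2)CC1` gives the lowest number of the three measured, 18 nM in an assay on THP-1 cells for displacement of a labelled ligand from C-C chemokine receptor type 1 (Homo sapiens); on this read-out lower numbers stand for stronger inhibition and higher numbers for weaker inhibition. Its nearest neighbour is compound 2 `Cc1ccc(C(=O)N[C@@H](C(=O)N2CCC(c3ccc(Cl)cc3)CC2)C(C)C)cc1` at 25 nM; the furthest is compound 1 `Cc1ccc(CCC(=O)N[C@@H](C(=O)N2CCC(c3ccc(Cl)cc3)CC2)C(C)C)cc1` at 105 nM. The steps of a 4.2-fold lower number from compound 1 to compound 2 (0.62 log units; beyond the scatter) and a 5.8-fold lower number from compound 1 to compound 3 (0.77 log units; beyond the scatter) are modest, whereas a 1.4-fold lower number from compound 2 to compound 3 (0.14 log units; within the scatter) lies within the scatter. Compound 4 `Cc1ccccc1C(=O)N[C@@H](C(=O)N1CCC(c2ccc(Cl)cc2)CC1)C(C)C` differs from compound 3 by 2-methylphenyl in place of 1,3-benzothiazol-2-yl on a carbonyl carbon. As far as these compounds go, the step bearing on this is a 1.4-fold lower number from compound 2 to compound 3 (0.14 log units; within the scatter), which shows that a methyl-bearing phenyl and the 1,3-benzothiazol-2-yl on the carbonyl carbon give numbers within the scatter of each other; how the 2-methylphenyl compares with the 4-methylphenyl is untested, so the range is kept wide. Compound 4 is therefore expected near 40 nM (range 12 nM to 130 nM), an estimated step of a 2.2-fold higher number from compound 3 to compound 4 (0.35 log units; beyond the scatter) in this assay.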

Compound 4, half-maximal inhibitory concentration: 32 nM
Estimate against measurement, compound 4: 1.3-fold (0.10 log units) above, and the stated range covers the measured number.
By their numbers in this assay, from the lowest: compounds 3, 2 and 4 (each within the scatter of the next); then compound 1.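

On the carbonyl carbon, the 2-methylphenyl group joins 4-methylphenyl and 1,3-benzothiazol-2-yl as indistinguishable in this assay: with a 1.3-fold higher number from compound 2 to compound 4 (0.11 log units; within the scatter) and a 1.8-fold higher number from compound 3 to compound 4 (0.25 log units; within the scatter), this read-out does not resolve where the methyl sits on the phenyl ring. Only the 2-(4-methylphenyl)ethyl group stands apart, with a 3.3-fold lower number from compound 1 to compound 4 (0.52 log units; beyond the scatter). No supporting data bear on these numbers. As far as these compounds go, it remains open whether a benzyl group on the carbonyl carbon would fall with the directly attached aryl groups or with the 2-(4-methylphenyl)ethyl compound. Also open, from the compounds shown here alone, is how an aminophenyl or carboxyphenyl group would compare.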